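Replacing the Nitro Group of Compound 2 with Hydrogen

A few compounds are considered here, and "the series" means these few. Any claim that something is new, unique, unknown or untested is made for them only; others in the source may bear on it.

Two compounds built on a shared core have numbers in a functional assay on HUVEC cells (Homo sapiens) for antiproliferative activity, read by MTT assay, with a stated time of 48 h; on this read-out lower numbers stand for stronger inhibition and higher numbers for weaker inhibition. Compound 1 `Cc1ccc(/C=C/c2nnc(-c3ccc4c(c3)OCCO4)o2)cc1` gives 45200 nM, and compound 2 `O=[N+]([O-])c1ccccc1/C=C/c1nnc(-c2ccc3c(c2)OCCO3)o1` gives 25000 nM. These two numbers lie within the usual scatter of each other, so compound 2 cannot be ranked apart from compound 1.

Compound 3 `C(=C/c1nnc(-c2ccc3c(c2)OCCO3)o1)\c1ccccc1` departs from compound 2 in one place: hydrogen in place of nitro on an aromatic carbon. Hydrogen stands in place of nitro on an aromatic carbon of a six-membered aromatic ring of carbon only. For the measured compounds named here, no measured pair shows what a single change of this kind does in this assay. Going by the values given here, the only guide is that compound 1 and compound 2 give numbers within the scatter of each other, although their structures differ. A large shift is therefore not expected, and no change beyond the scatter is anticipated in either direction. The expected step is a 1.4-fold higher number from compound 2 to compound 3 (0.15 log units; within the scatter), which would remain within the scatter. For compound 3 the estimated value is 35000 nM, with an expected range from 15000 nM to 80000 nM.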

Compound 3, half-maximal inhibitory concentration: > 50000 nM
Compound 3: a limit, no number (the forecaster's own chance of this, stated with the estimate: 10%); middle value at least 1.4-fold (0.15 log units) from the limit.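

In this assay, compound 3, with hydrogen on the aromatic carbon that carries nitro in compound 2, ends at a limit and not a number: the limit of > 50000 nM in this assay, at which 1 of the 3 values shown sits.

For the compounds shown here, this provides the first steps that turn on a single change: hydrogen in place of nitro gives an at least 2.0-fold higher number from compound 2 to compound 3 (0.30 log units; that floor lies within the scatter), and hydrogen in place of methyl gives an at least 1.1-fold higher number from compound 1 to compound 3 (0.04 log units; that floor lies within the scatter). Both are floors rather than measured sizes, so they set only the least each step can be, and neither floor shows a difference beyond the scatter, although the true steps could be larger.

On these data alone, what stays open is how far the number for compound 3 lies past the limit, and therefore whether removing either group matters at all in this assay. As far as these compounds go, it is also open whether any effect belongs to nitro in particular or would be shared by other groups on that aromatic carbon, ortho to a large group, such as an amine, a chlorine atom or a carboxylic acid.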